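Swapping hydroxy for ureido on a double-bonded nitrogen

A few compounds are considered here, and "the series" means these few. Any claim that something is new, unique, unknown or untested is made for them only; others in the source may bear on it.

- Compound 1 `C/C(=N\O)c1ccc2[nH]c(-c3ccc(Cl)cc3)nc2c1`: 37000 nM
- Compound 2 `C/C(=N\O)c1ccc2[nH]c(-c3ccc(C(F)(F)F)cc3)nc2c1`: 55000 nM

In an ADME assay on MDBK cells (Bos taurus) for cytotoxicity, read by MTT assay, with a stated time of 96 h (a higher number here means that more compound is tolerated, a lower number that less compound is tolerated), compound 1 and compound 2 lie within the scatter of each other, so compound 1 holds no distinct place on these numbers.

Compound 3 `C/C(=N\NC(N)=O)c1ccc2[nH]c(-c3ccc(Cl)cc3)nc2c1` has not yet been measured. It keeps the core of compound 1 and differs in one place: ureido in place of hydroxy on a double-bonded nitrogen. Among the compounds with values here, the only measured step is a 1.5-fold higher number from compound 1 to compound 2 (0.17 log units; within the scatter). That step stays within the scatter, but it is trifluoromethyl in place of chloro on an aromatic carbon, a change elsewhere in the structure, so it bears only weakly on this one. Within the data shown here, no measured compound carries ureido, so the data give no direction, and no step beyond the scatter is expected, though with wide uncertainty.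

The estimate amounts to an expected 1.1-fold higher number from compound 1 to compound 3 (0.03 log units; within the scatter).

For compound 3 the expected value is 40000 nM, with an estimated range from 15000 nM to 100000 nM.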

Compound 3, half-maximal cytotoxic concentration: > 100000 nM
Compound 3: a limit, no number (the forecaster's own chance of this, stated with the estimate: 25%); middle value at least 2.5-fold (0.39 log units) from the limit.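

In this assay, the double-bonded nitrogen proves to be a place where a single change moves the number beyond the scatter: ureido in place of hydroxy gives an at least 2.7-fold higher number from compound 1 to compound 3 (0.43 log units; beyond the scatter). Within the data shown here, the one earlier step, a 1.5-fold higher number from compound 1 to compound 2 (0.17 log units; within the scatter), stayed within the scatter and concerned an aromatic carbon, so it showed nothing about this position. The result for compound 3 is a limit of the assay and not a number: the limit of > 100000 nM in this assay, at which 1 of the 3 values shown sits.

From the compounds shown here alone, how far compound 3 lies past that limit stays open, so this step has a lower bound but no exact size. Also open, going by these compounds, is whether a smaller group on the same nitrogen, such as methoxy or a plain amine, would shift the number as ureido does, and whether ureido would do the same alongside trifluoromethyl in place of chloro.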